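The source may hold more compounds than are shown below. What is called first, only, known or untested is meant among the compounds shown, and "the series" means these compounds.

Three related compounds have been tested so far in a functional assay on HOP-92 cells (Homo sapiens) for inhibition, with a stated time of 48 h; a higher number here means a weaker inhibitor of growth, a lower number a stronger inhibitor of growth. Compound 1 (`COc1ccccc1/C=C/C(=O)c1c(O)cc2occc2c1OC`) gives 2980 nM, compound 2 (`COc1c(C(=O)/C=C/c2ccc(Cl)cc2)c(O)c(Br)c2occc12`) gives 1390 nM and compound 3 (`C=CCc1c(O)c(C(=O)/C=C/c2ccccc2)c(OC)c2ccoc12`) gives 1330 nM. Compound 3 therefore stands level with compound 2, as their two values lie within the usual scatter of repeated measurements. Compound 1 has a higher number than compound 3 by more than that scatter, which makes it the weaker inhibitor of the two.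

Compound 4 (`C=CCc1c(O)c(C(=O)/C=C/c2ccc(Cl)cc2)c(OC)c2ccoc12`) is compound 3 with a single change: chloro in place of hydrogen on an aromatic carbon. This places chloro in place of hydrogen on an aromatic carbon, turning phenyl to 4-chlorophenyl. For the measured compounds named here, no two tested compounds differ by this change alone, so the data offer no direct measure of it. Compound 2 does carry the 4-chlorophenyl, although it also differs from compound 3 elsewhere. The value of compound 2, 1390 nM, gives no sign of a large shift. No change beyond the scatter is therefore expected in this assay, in either direction. The expected step of a 1.1-fold lower number from compound 3 to compound 4 (0.03 log units; within the scatter) is small. For compound 4 the estimated value is 1250 nM, with an expected range of 550 nM to 2800 nM.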

Compound 4, concentration for 50% growth inhibition: 1690 nM
Compound 4: middle estimate off by 1.4-fold (0.13 log units), on the low side, and the stated range covers the measured number.
By their numbers in this assay, from the lowest: compounds 3, 2, 4 and 1 (each within the scatter of the next, the first and the last beyond it).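

In this assay, chloro in place of hydrogen on an aromatic carbon, para to a large group, can now be read directly: turning phenyl to 4-chlorophenyl gives a 1.3-fold higher number from compound 3 to compound 4 (0.10 log units; within the scatter), so the two compounds cannot be told apart in this measurement. A second comparison, with the 4-chlorophenyl kept in both compounds, reads allyl in place of bromo on an aromatic carbon and gives a 1.2-fold higher number from compound 2 to compound 4 (0.08 log units; within the scatter), so this exchange also cannot be told apart from repeated-measurement noise. No measurement is available that could explain why either exchange leaves the number within the scatter.

The compounds shown leave open whether an amine or a carboxylic acid at the same place on the phenyl ring would move the number beyond the scatter, since only hydrogen and chloro can be compared there. They also leave open whether a longer chain in place of allyl would do so, and whether chloro would give the same small step if the other groups on the shared core were different.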